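The source may hold more compounds than are shown below. What is called first, only, known or untested is meant among the compounds shown, and "the series" means these compounds.

- Compound 1 `CC(=O)NCC(=O)Nc1ccc(Cl)cc1C(=O)c1ccccc1`: 37 mg/kg
- Compound 2 `CN(C(=O)CNC(=O)CN1CCCCC1)c1ccc(Cl)cc1C(=O)c1ccccc1Cl`: 7.5 mg/kg

In a functional assay on the whole organism for antagonist activity, with Mus musculus as the target (on this read-out higher numbers stand for an effect only at larger amounts of compound and lower numbers for an effect already at smaller amounts), compound 2 has the lower of the two numbers, at 7.5 mg/kg, and its gap to compound 1 lies beyond the scatter. Compound 3 `CCCCCC(=O)NCC(=O)N(C)c1ccc(Cl)cc1C(=O)c1ccccc1Cl` follows from compound 2 by one change: butyl in place of piperidin-1-yl on a saturated chain carbon bound to a carbonyl carbon. Butyl replaces piperidin-1-yl on a saturated chain carbon bound to a carbonyl carbon. Within the data shown here, no measured step shows this change, so any forecast is tentative. Among the measured compounds shown here, the only higher reference is compound 1 at 37 mg/kg. A moderate rise in the number is expected, a 2.7-fold higher number from compound 2 to compound 3 (0.43 log units; beyond the scatter). For compound 3, the estimated value in this assay is 20 mg/kg, with an expected range from 6 mg/kg to 70 mg/kg.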

Compound 3, dose for half-maximal effect: 1.9 mg/kg
The estimate for compound 3 lay 11-fold (1.02 log units) above the measured number, outside the stated range (below it).
By their numbers in this assay, from the lowest: compound 3; then compound 2; then compound 1.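

In this assay, among these compounds, butyl in place of piperidin-1-yl on a saturated chain carbon bound to a carbonyl carbon gives a 3.9-fold lower number from compound 2 to compound 3 (0.60 log units; beyond the scatter) and this is the only single-place step in the set. It shows that a low number at this place needs neither the ring nor the nitrogen of piperidin-1-yl, and that an open carbon chain is accepted there. Nothing at hand accounts for the size of this step. On these data alone, how a longer chain or a morpholine ring would read at this place stays open. So does whether the step would hold on the core of compound 1.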